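Chloro on the second phenyl of compound 2

A few compounds are considered here, and "the series" means these few. Any claim that something is new, unique, unknown or untested is made for them only; others in the source may bear on it.

The series rests on a shared core carrying a nitrile. Compound 1 `Cn1c(N2N=C(c3ccccc3)CC2c2ccc(Cl)cc2)nc(-c2ccccc2)c(C#N)c1=O` gives 19200 nM in a functional assay on HT-29 cells (Homo sapiens) for antiproliferative activity, with a stated time of 72 h; on this read-out higher numbers stand for weaker inhibition and lower numbers for stronger inhibition. Compound 2 `Cn1c(N2N=C(c3ccccc3)CC2c2ccc(F)cc2)nc(-c2ccccc2)c(C#N)c1=O` stands second highest of the three numbers with 8150 nM; compound 3 `Cc1ccc(C2=NN(c3nc(-c4ccccc4)c(C#N)c(=O)n3C)C(c3ccc(F)cc3)C2)cc1` gives 4620 nM. The step of a 2.4-fold lower number from compound 1 to compound 2 (0.37 log units; beyond the scatter) is modest, and the step of a 1.8-fold lower number from compound 2 to compound 3 (0.25 log units; within the scatter) stays within the scatter. Compound 4 `Cn1c(N2N=C(c3ccccc3)CC2c2ccc(F)cc2)nc(-c2ccc(Cl)cc2)c(C#N)c1=O` differs from compound 2 by chloro in place of hydrogen on an aromatic carbon. Among the measured compounds shown here, no measured step touches this phenyl, and the two known steps on other rings were small, so no change beyond the scatter is expected for compound 4. The expected step is a 1.3-fold lower number from compound 2 to compound 4 (0.10 log units; within the scatter). Compound 4 is accordingly estimated at 6500 nM, within the range 2500 nM to 17000 nM.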

Compound 4, half-maximal inhibitory concentration: 13700 nM
Beside the measured number, compound 4's estimate is 2.1-fold (0.32 log units) below it; low and high end bracket the measured number.
By their numbers in this assay, from the lowest: compounds 3, 2, 4 and 1 (each within the scatter of the next, the first and the last beyond it).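

Going from phenyl to 4-chlorophenyl on this ring gives a 1.7-fold higher number from compound 2 to compound 4 (0.23 log units; within the scatter) in this assay. Among the compounds shown here, the earlier steps all lay on other rings, so this is the only reading for this position, and in this single case chloro produces no step beyond the scatter. No measurement available here accounts for this result.

The compounds shown leave open whether an amine or a carboxylic acid in the same place would move the number beyond the scatter.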